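From 6-methylpyridin-3-yl to 6-methoxypyridin-3-yl: working notes

The source may hold more compounds than are shown below. What is called first, only, known or untested is meant among the compounds shown, and "the series" means these compounds.

Measured in an ADME assay (liver) for metabolic stability, with Liver microsome (Homo sapiens) as the target, using microsomes and NADPH, with a stated time of 30 min, tested at 1 uM (a lower number here means slower removal, a higher number faster removal of the compound), so far
compound 1 `COc1cc(C(O)(C(F)(F)F)C(F)(F)F)cnc1N1CCN(S(=O)(=O)c2ccc(N)nc2)CC1` gives < 14 mL.min-1.g-1 which is a limit of the assay and not a number
compound 2 `Nc1ccc(S(=O)(=O)N2CCN(c3ncc(C(O)(C(F)(F)F)C(F)(F)F)cc3-c3cncc(F)c3)CC2)cn1` gives 24 mL.min-1.g-1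
compound 3 `Cc1ccc(-c2cc(C(O)(C(F)(F)F)C(F)(F)F)cnc2N2CCN(S(=O)(=O)c3ccc(N)nc3)CC2)cn1` gives 43 mL.min-1.g-1

Compound 3 stands at 43 mL.min-1.g-1 in this assay and lies within the scatter of compound 2, its nearest number. Compound 4 `COc1ccc(-c2cc(C(O)(C(F)(F)F)C(F)(F)F)cnc2N2CCN(S(=O)(=O)c3ccc(N)nc3)CC2)cn1` differs from compound 3 by methoxy in place of methyl on an aromatic carbon with methoxy in place of methyl on an aromatic carbon, next to the ring nitrogen and para to a large group.

Among the compounds with values here, no measured step makes this exact change. Replacing methoxy on the shared core with 6-methylpyridin-3-yl gave an at least 3.0-fold higher number from compound 1 to compound 3 (0.48 log units; beyond the scatter) while 5-fluoropyridin-3-yl in the same place gave an at least 1.7-fold higher number from compound 1 to compound 2 (0.23 log units; that floor lies within the scatter) but both steps start from a limit and concern a different exchange. The closer guide is the swap of 5-fluoropyridin-3-yl for 6-methylpyridin-3-yl, which gave a 1.8-fold higher number from compound 2 to compound 3 (0.25 log units; within the scatter) and so stayed small. On that basis a step of similar small size is expected, with no firm direction and nothing beyond the scatter. The estimated change is a 1.1-fold lower number from compound 3 to compound 4 (0.05 log units; within the scatter) in this reading. For compound 4 the expected value is 38 mL.min-1.g-1 with an estimated range of 19 mL.min-1.g-1 to 75 mL.min-1.g-1 in this assay for now.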

Compound 4, intrinsic clearance in microsomes: 25 mL.min-1.g-1
The estimate for compound 4 lay 1.5-fold (0.18 log units) above the measured number; the measured number falls inside the stated range.
By their numbers in this assay, from the lowest: compounds 2, 4 and 3 (each within the scatter of the next). At a limit, below all of these: compound 1.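

In this assay, the exchange of methyl for methoxy next to the ring nitrogen and para to a large group now has a direct reading, a 1.7-fold lower number from compound 3 to compound 4 (0.24 log units; within the scatter), while the comparison with the fluorinated ring gives a 1.0-fold higher number from compound 2 to compound 4 (0.02 log units; within the scatter), so neither step separates these groups beyond the scatter. Against the methoxy on the shared core, the reading is an at least 1.7-fold higher number from compound 1 to compound 4 (0.25 log units; that floor lies within the scatter), which gives only a floor and does not establish that the added ring raises the number. Compound 1 stands at a limit and not a number: the limit of < 14 mL.min-1.g-1 in this assay, at which 1 of the 4 values shown sits.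

From the compounds shown here alone, whether an amine or a longer chain such as ethoxy at this position would produce a step beyond the scatter remains open, since the three groups read here cover only methyl, methoxy and a fluorine on a different ring position. Also open is whether the exchange of methyl for methoxy would read the same on a core carrying a different group in place of the sulfonyl-linked aminopyridine, and which part of these compounds accounts for their removal in this assay.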